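One ring exchanged on compound 3

This account rests on a few compounds, and the source may have more. Where it says the series, first, only, none or still open, it means among the compounds named here.

Of the compounds shown here, three sharing one core have been measured in an ADME assay on the whole organism (plasma, Rattus norvegicus) for protein binding, using cassette dosing, at a dose of 1 mg/kg; on this read-out lower numbers stand for a smaller free fraction and higher numbers for a larger free fraction. Compound 1 (`C[C@@H](Cn1c(=O)[nH]/c(=N\c2ccc(Oc3nccs3)cc2)n(Cc2ccc(Cl)cc2)c1=O)C(=O)O`) gives 0.006, compound 2 (`C[C@@H](Cn1c(=O)[nH]/c(=N\c2ccc(Oc3cncc(F)c3)cc2)n(Cc2ccc(Cl)cc2)c1=O)C(=O)O`) gives 0.02, and compound 3 (`C[C@@H](Cn1c(=O)[nH]/c(=N\c2ccc(Oc3cnccn3)cc2)n(Cc2ccc(Cl)cc2)c1=O)C(=O)O`) gives 0.018. Compound 3 therefore stands clear of the low number of compound 1 but cannot be told apart from compound 2.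

Compound 4 (`C[C@@H](Cn1c(=O)[nH]/c(=N\c2ccc(Oc3cccc(F)n3)cc2)n(Cc2ccc(Cl)cc2)c1=O)C(=O)O`) carries 6-fluoropyridin-2-yl in place of pyrazin-2-yl on an oxygen on an aromatic ring.

Among the measured compounds shown here, no measured compound carries this exact group, so the nearest guide is the other exchanges at that oxygen. Moving between the two six-membered rings measured so far changed little, with a 1.1-fold lower number from compound 2 to compound 3 (0.05 log units; within the scatter). Only the exchanges away from 1,3-thiazol-2-yl went beyond the scatter, with a 3.3-fold higher number from compound 1 to compound 2 (0.52 log units; beyond the scatter) and a 3.0-fold higher number from compound 1 to compound 3 (0.48 log units; beyond the scatter), and both were modest.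

The new group is also a six-membered ring, so the expected change is small and within the scatter, with an estimated 1.2-fold lower number from compound 3 to compound 4 (0.08 log units; within the scatter). Compound 4 is estimated at 0.015, with an expected range of 0.007 to 0.03.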

Compound 4, unbound fraction: 0.007
Beside the measured number, compound 4's estimate is 2.1-fold (0.33 log units) above it; the measured number falls inside the stated range.
By their numbers in this assay, from the lowest: compounds 1 and 4 (each within the scatter of the next); then compounds 3 and 2 (each within the scatter of the next).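

Being a six-membered ring is not enough to hold the free fraction at this oxygen in this assay, as the exchange of pyrazin-2-yl for 6-fluoropyridin-2-yl gives a 2.6-fold lower number from compound 3 to compound 4 (0.41 log units; beyond the scatter). Even two fluorinated pyridine rings can differ, with a 2.9-fold lower number from compound 2 to compound 4 (0.46 log units; beyond the scatter), while the thiazole and 6-fluoropyridin-2-yl cannot be told apart, with a 1.2-fold higher number from compound 1 to compound 4 (0.07 log units; within the scatter), so the identity of the whole ring counts here rather than its size. Nothing available explains these differences.

The compounds shown cannot separate the part played by the fluorine from that of the way the ring is attached. Plain pyridin-2-yl, or 6-aminopyridin-2-yl, on the same oxygen would show whether the low number stays with that ring when the fluorine is absent or replaced.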